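Cytotoxicity limits in a piperidinyl-piperidine sulfonamide series

The source may report more compounds than this note shows. Statements on the series, on what has been measured and on what is new or still open speak of the compounds shown alone.

Measured so far:
compound 1 `CC1CCN(C2CCN(S(=O)(=O)c3cccc(-c4ccccc4C(F)(F)F)c3)CC2)CC1` — > 5000 nM
compound 2 `CC1CCN(C2CCN(S(=O)(=O)c3cn(C)cn3)CC2)CC1` — > 10000 nM

In an ADME assay on HCT-116 cells (Homo sapiens) for cytotoxicity, read by CellTiter-Glo, with a stated time of 72 h (a higher number here means a weaker inhibitor, a lower number a stronger inhibitor), compound 2 gives > 10000 nM, which is a limit of the assay and not a number. Compound 1 likewise gives only a limit in this assay, > 5000 nM. Among the compounds with values here, both values therefore sit at limits, one at the limit of > 10000 nM in this assay, at which 1 of the 2 values shown sits, and the other at the limit of > 5000 nM in this assay, at which 1 of the 2 values shown sits, and no measured step between two numbers is available.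

Compound 3 `CCc1ccc(S(=O)(=O)N2CCC(N3CCC(C)CC3)CC2)cc1` is not yet measured. It differs from compound 2 by 4-ethylphenyl in place of 1-methyl-1H-imidazol-4-yl on a sulfonyl sulfur. Within the data shown here, with both known values at limits, no measured step supports a directional expectation; the change is expected to leave compound 3 at or near a limit as well, so the step that the limit leaves unreadable from compound 2 to compound 3 is estimated as none beyond the scatter. Compound 3 is expected to give about 15000 nM in this assay, within 5000 nM to 50000 nM.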

Compound 3, half-maximal inhibitory concentration: > 5000 nM
Compound 3 ended at the assay's limit; the forecaster's own chance of this, stated with the estimate: 75%; the middle value lies beyond the limit too.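

In this assay compound 3 gives > 5000 nM, which is a limit of the assay and not a number. Compound 2 also stands at a limit, and the step from compound 2 to compound 3 cannot be read. The compounds shown leave open where any of the three would reach half-maximal inhibition.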